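The compounds below may be only part of what the source reports. "The series", "measured", "known", "first", "only" and "open" are said of these compounds alone.

In a physicochemical assay for solubility, at pH 7.4 (a higher number here means a more soluble compound, a lower number a less soluble compound), three compounds sharing one core have been measured. Compound 1 `O=C(N[C@H]1CN(S(=O)(=O)c2ccccc2)C[C@@H]1C(=O)N[C@H]1CCCNC1)c1cc(-c2ccccc2Cl)on1` gives 12000 nM. Compound 2 `CN(C(=O)[C@H]1CN(S(=O)(=O)c2ccccc2)C[C@@H]1NC(=O)c1cc(-c2ccccc2Cl)on1)[C@H]1CCCNC1` gives 113000 nM. Compound 3 `CN1CCC[C@H](NC(=O)[C@H]2CN(S(=O)(=O)c3ccccc3)C[C@@H]2NC(=O)c2cc(-c3ccccc3Cl)on2)C1` gives 503000 nM, the highest number of the three, clear of both others.

Compound 4 `CC(=O)N1CCC[C@H](NC(=O)[C@H]2CN(S(=O)(=O)c3ccccc3)C[C@@H]2NC(=O)c2cc(-c3ccccc3Cl)on2)C1`, still unmeasured, departs from compound 3 at one place: acetyl in place of methyl on an amine nitrogen in a ring. Put another way, 1-methylpiperidin-3-yl becomes 1-acetylpiperidin-3-yl.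

The measured change closest to this one sits on the same ring nitrogen, where methyl replaces hydrogen: a 42-fold higher number from compound 1 to compound 3 (1.62 log units; beyond the scatter), a large step. Two modest steps bear on it less directly. One is a 9.4-fold higher number from compound 1 to compound 2 (0.97 log units; beyond the scatter), with methyl on an amide-type nitrogen instead. The other is a 4.5-fold higher number from compound 2 to compound 3 (0.65 log units; beyond the scatter), which moves the methyl between those two nitrogens.

These steps show that small edits in this series can shift the number well beyond the scatter. Among the compounds with values here, no measured compound carries acetyl, however, so the direction remains a judgement. Within the data shown here, with compound 3 already at 503000 nM and no measured compound higher, a modest step to a lower number is expected. The expected change is a 6.3-fold lower number from compound 3 to compound 4 (0.80 log units; beyond the scatter). For compound 4 the estimate is 80000 nM, with an expected range from 15000 nM to 350000 nM.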

Compound 4, solubility: < 500 nM
Compound 4: no number, only a limit (the forecaster's own chance of this, stated with the estimate: 10%); at least 160-fold (2.20 log units) between middle value and limit.
By their numbers in this assay, from the lowest: compound 1; then compound 2; then compound 3. At a limit, below all of these: compound 4.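

In this assay, within the data shown here, the amine nitrogen in the ring had until now been seen only with hydrogen or methyl, and acetyl is the first group there to bring the number down, with an at least 1000-fold lower number from compound 3 to compound 4 (3.00 log units; beyond the scatter). The drop is not simply the loss of the methyl, since acetyl also falls short of hydrogen on the same nitrogen, with an at least 24-fold lower number from compound 1 to compound 4 (1.38 log units; beyond the scatter), and the compound with its methyl on the amide-type nitrogen also stands higher, with an at least 220-fold lower number from compound 2 to compound 4 (2.35 log units; beyond the scatter). For compound 4 the read-out is a limit of the assay and not a number: the limit of < 500 nM in this assay, at which 1 of the 4 values shown sits.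

The compounds shown leave open whether this fall belongs to acetyl alone or would also follow from another group on this nitrogen, such as an ethyl group, a longer chain, a carboxylic acid or a sulfonyl group. They also leave open whether acetyl would give a similar fall elsewhere on the shared core, for instance on the amide-type nitrogen that carries the methyl in compound 2.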